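The compounds below may be only part of what the source reports. "The series", "measured", "known", "first", "only" and "open" are said of these compounds alone.

Measured in a functional assay on A-431 cells (Homo sapiens) for antiproliferative activity, read by MTT assay, with a stated time of 72 h; on this read-out higher numbers stand for weaker inhibition and lower numbers for stronger inhibition:
Compound 1, `COc1cc2ncnc(Nc3ccc(F)c(Cl)c3)c2cc1OCCCCC(=O)Nc1ccc(S(N)(=O)=O)cc1`, gives 5020 nM.
Compound 2, `COc1cc2ncnc(Nc3ccc(Cl)c(C(F)(F)F)c3)c2cc1OCCCCC(=O)Nc1ccc(S(N)(=O)=O)cc1`, gives 3910 nM.
Compound 3, `COc1cc2ncnc(Nc3cccc(Cl)c3)c2cc1OCCCCC(=O)Nc1ccc(S(N)(=O)=O)cc1`, gives 30400 nM.

Compound 3 carries the highest number of the three and is therefore the weakest inhibitor in this set: the steps of a 6.1-fold higher number from compound 1 to compound 3 (0.78 log units; beyond the scatter) and a 7.8-fold higher number from compound 2 to compound 3 (0.89 log units; beyond the scatter) both lie beyond the scatter, whereas a 1.3-fold lower number from compound 1 to compound 2 (0.11 log units; within the scatter) does not. Compound 4, `COc1cc2ncnc(Nc3cccc(F)c3)c2cc1OCCCCC(=O)Nc1ccc(S(N)(=O)=O)cc1`, is obtained from compound 3 by a single exchange of halogens: fluoro in place of chloro on an aromatic carbon. For the measured compounds named here, no measured pair tests exactly this swap. The two steps that arrive at compound 3 instead take a fluoro off the same ring and replace it with hydrogen, and each costs a modest amount, so changes on this ring do register, but they give no direct reading on chloro against fluoro. With no direct guide, compound 4 is expected to remain near compound 3 in this assay, perhaps a little weaker, which corresponds to an estimated step of a 1.5-fold higher number from compound 3 to compound 4 (0.17 log units; within the scatter). Compound 4 is accordingly estimated at 45000 nM, with a range from 15000 nM to 130000 nM.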

Compound 4, half-maximal inhibitory concentration: 29900 nM
Compound 4: middle estimate off by 1.5-fold (0.18 log units), on the high side; the range from low to high includes it.
By their numbers in this assay, from the lowest: compounds 2 and 1 (each within the scatter of the next); then compounds 4 and 3 (each within the scatter of the next).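

In this assay, fluoro in place of chloro on this aromatic carbon, meta to a large group, leaves the number within the scatter (a 1.0-fold lower number from compound 3 to compound 4 (0.01 log units; within the scatter)), so at this position the two halogens cannot be told apart. The 3-fluorophenyl compound still has a higher number than the two compounds with more heavily substituted rings, and both steps lie beyond the scatter (a 6.0-fold higher number from compound 1 to compound 4 (0.77 log units; beyond the scatter); a 7.6-fold higher number from compound 2 to compound 4 (0.88 log units; beyond the scatter)). Nothing measured here accounts for the halogen exchange making so little difference.

Going by these compounds, it remains open whether bromo, methoxy or an amine at this carbon would shift the number. The compounds also leave open whether the same exchange would be as silent on the ring of compound 1, which carries a second halogen.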